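The source may report more compounds than this note shows. Statements on the series, on what has been measured and on what is new or still open speak of the compounds shown alone.

Of the compounds shown here, three built on one shared core have been tested in a functional assay on K562 cells (Homo sapiens) for inhibition, read by trypan blue exclusion, with a stated time of 72 h; a lower number here means a stronger inhibitor, a higher number a weaker inhibitor. Compound 2 `Cn1c(=O)c(S(=O)(=O)c2ccc(C(=O)O)cc2)cc2cnc(Nc3ccc4[nH]ccc4c3)nc21` gives 5000 nM in this assay. Compound 1 `COC(=O)Cn1c(=O)c(S(=O)(=O)c2ccc(F)cc2F)cc2cnc(Nc3ccc4[nH]ccc4c3)nc21` gives 5000 nM, the same number at the digits shown, so the two sit level. Compound 3 `Cn1c(=O)c(S(=O)(=O)c2ccccc2)cc2cnc(Nc3ccc4cc[nH]c4c3)nc21` gives 10000 nM, and its gap to compound 2 lies within the usual scatter, so no ranking of the three can be claimed. Compound 4 `Cn1c(=O)c(S(=O)(=O)c2ccc(F)cc2N)cc2cnc(Nc3ccc4[nH]ccc4c3)nc21` has not yet been measured. It differs from compound 2 by 2-amino-4-fluorophenyl in place of 4-carboxyphenyl on a sulfonyl sulfur. Among the measured compounds shown here, no measured pair shows a single change of this kind, and the three known numbers all sit close together, so nothing points to a step beyond the scatter. The estimate for compound 4 in this assay is 5000 nM, with a range from 2000 nM to 15000 nM. The expected step of no change at the digits printed from compound 2 to compound 4 (within the scatter) is accordingly essentially none.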

Compound 4, half-maximal inhibitory concentration: 2000 nM
Estimate against measurement, compound 4: 2.5-fold (0.40 log units) above, within the range that was stated.
By their numbers in this assay, from the lowest: compound 4; then compounds 1, 2 and 3 (each within the scatter of the next).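

In this assay, among the compounds shown here, the place on the sulfonyl sulfur proves able to move the number: 2-amino-4-fluorophenyl in place of 4-carboxyphenyl gives a 2.5-fold lower number from compound 2 to compound 4 (0.40 log units; beyond the scatter) and this modest step is the first beyond the scatter in the set. Both groups count one hydrogen-bond donor and one hydrogen-bond acceptor, so those counts do not separate them. No measurement here accounts for the step.

Still open, as far as these compounds go, is which part of the change carries the step: the amine, the fluorine or the loss of the carboxylic acid. A 2-aminophenyl or a 4-fluorophenyl group in this place on the core of compound 2 would help separate these.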